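Thiophene-pyrimidine anilines: swapping the piperidine for imidazole

This account rests on a few compounds, and the source may have more. Where it says the series, first, only, none or still open, it means among the compounds named here.

Measured so far:
compound 1 `CC1CCN(c2ccc(Nc3nccc(-c4cccs4)n3)cc2)CC1` — 400 nM
compound 2 `CC1CCN(c2ccc(Nc3nccc(-c4ccncc4)n3)cc2)CC1` — 600 nM

Both values come from a functional assay for inhibition, with Homo sapiens as the target; on this read-out lower numbers stand for stronger inhibition and higher numbers for weaker inhibition. Compound 1 holds the lowest of the two numbers; compound 2 sits within the scatter of it, the step of a 1.5-fold higher number from compound 1 to compound 2 (0.18 log units; within the scatter) being too small to read as a change. That step alters only the ring on the pyrimidine and leaves the other end of the molecule untouched.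

Compound 3 `c1csc(-c2ccnc(Nc3ccc(-n4ccnc4)cc3)n2)c1` is not yet measured. Relative to compound 1 the change is 1H-imidazol-1-yl in place of 4-methylpiperidin-1-yl on an aromatic carbon. Within the data shown here, no measured step touches this position, so nothing shows how the replacement acts; the one recorded step, from compound 1 to compound 2, concerns a different part of the core. The expectation for compound 3 therefore rests on compound 1 alone, with a wide range and no direction claimed beyond the scatter. The step from compound 1 to compound 3 is estimated as a 2.0-fold higher number from compound 1 to compound 3 (0.30 log units; within the scatter). For compound 3 the expected value in this assay is 800 nM, between 200 nM and 3200 nM.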

Compound 3, half-maximal inhibitory concentration: 4300 nM
Compound 3: middle estimate off by 5.4-fold (0.73 log units), on the low side; measured number above the stated range.
By their numbers in this assay, from the lowest: compounds 1 and 2 (each within the scatter of the next); then compound 3.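

In this assay this position turns out to be sensitive: the replacement of 4-methylpiperidin-1-yl by 1H-imidazol-1-yl gives an 11-fold higher number from compound 1 to compound 3 (1.03 log units; beyond the scatter), a large step beyond the scatter. Among these compounds, the only earlier step, a 1.5-fold higher number from compound 1 to compound 2 (0.18 log units; within the scatter), lay within the scatter and concerned the other end of the molecule, so compound 3 gives the first sign that the group on this aromatic carbon affects the number. No available measurement bears on the reason for this rise.

The single change alters ring size and aromatic character together, so the compounds shown do not separate the two. On these data alone, it remains open whether a morpholine ring or an open-chain dimethylamino group here would stay close to compound 1 or fall nearer compound 3, and whether 1H-imidazol-1-yl would act the same way on compound 2.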